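Nitrophenyl Swap on the Ring Nitrogen of Compound 3

The source may hold more compounds than are shown below. What is called first, only, known or untested is meant among the compounds shown, and "the series" means these compounds.

Compound 3 `COc1cccc(N2CCN(Cn3nc(-c4ccc5c(c4)OCCO5)oc3=S)CC2)c1` belongs to a small set of three analogues sharing one core, all tested in a functional assay on BGC-823 cells (Homo sapiens) for antiproliferative activity, read by MTT assay, with a stated time of 48 h; a higher number here means a weaker inhibitor, a lower number a stronger inhibitor. Compound 3 gives > 50000 nM, which is a limit of the assay rather than a number. Compound 1 `S=c1oc(-c2ccc3c(c2)OCCO3)nn1CN1CCN(c2ccc(Cl)cc2)CC1` likewise returns only a limit, > 50000 nM. Compound 2 `S=c1oc(-c2ccc3c(c2)OCCO3)nn1CN1CCN(c2ccccc2)CC1` also stops at a limit, > 50000 nM. All three values therefore sit at the limit of > 50000 nM in this assay, at which 3 of the 3 values shown sit, and the steps among them, a step that the two limits leave unreadable from compound 1 to compound 2, a step that the two limits leave unreadable from compound 1 to compound 3 and a step that the two limits leave unreadable from compound 2 to compound 3, carry no readable size in either direction.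

Compound 4 `O=[N+]([O-])c1ccc(N2CCN(Cn3nc(-c4ccc5c(c4)OCCO5)oc3=S)CC2)cc1` has not yet been measured in this assay. It differs from compound 3 by 4-nitrophenyl in place of 3-methoxyphenyl on an amine nitrogen in a ring. The measured steps that touch the same position, the aryl group on the ring nitrogen, are the three just named, and none of them can be read because every value stands at the limit of > 50000 nM in this assay, at which 3 of the 3 values shown sit. Nothing in the measured set points away from that limit.

On that basis compound 4 is expected to give 50000 nM, with a range from 20000 nM to 120000 nM. The estimated step of a number no higher from compound 3 to compound 4 (the limit leaves the size open) is thus expected to be none beyond the scatter, and most likely the assay will again report only a limit rather than a number.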

Compound 4, half-maximal inhibitory concentration: > 50000 nM
Compound 4 ended at the assay's limit; the forecaster's own chance of this, stated with the estimate: 75%; the middle value sits exactly at the limit.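

Compound 4 gives > 50000 nM in this assay and this is a limit of the assay, not a number. For the compounds shown here, no step linking compound 4 with compound 1, compound 2 or compound 3 can be read, because all four compounds stand at the same limit: the limit of > 50000 nM in this assay, at which 4 of the 4 values shown sit. In this assay the compounds shown leave open whether any aryl group on the ring nitrogen gives a readable value.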